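Truncation of the benzylic side chain in a pyridinone series

The source may hold more compounds than are shown below. What is called first, only, known or untested is meant among the compounds shown, and "the series" means these compounds.

Compound 1 `CCCCc1ccc(CNC(=O)N(C)C)c(=O)n1Cc1ccc(-c2ccccc2-c2nn[nH]n2)cc1` gives 2 nM in a functional assay (aorta) for antagonist activity, with Oryctolagus cuniculus as the target; a lower number here means a stronger inhibitor, a higher number a weaker inhibitor. Compound 2 `CCCCc1ccc(CN(C)S(=O)(=O)c2ccccc2)c(=O)n1Cc1ccc(-c2ccccc2-c2nn[nH]n2)cc1` gives 2 nM in this assay, and the step of no change at the digits printed from compound 1 to compound 2 (within the scatter) shows that exchanging one substituent for another at this position leaves the read-out where it was. Compound 2 therefore stands level with compound 1 on the numbers shown, with no other measured neighbour. Compound 3 `CCCCc1ccc(C)c(=O)n1Cc1ccc(-c2ccccc2-c2nn[nH]n2)cc1` carries the change (hydrogen in place of methyl(phenylsulfonyl)amino on a saturated chain carbon bound to an aromatic carbon), so the whole substituent is removed rather than exchanged. For the measured compounds named here, no measured step bears directly on this; the step of no change at the digits printed from compound 1 to compound 2 (within the scatter) only indicates that the two substituents tried so far contribute alike, not whether their presence matters. Going by the values given here, with no measured step of this kind, a moderate loss in this assay is expected for compound 3, written as a 6.0-fold higher number from compound 2 to compound 3 (0.78 log units; beyond the scatter). Compound 3 is estimated at 12 nM, with a range from 2 nM to 80 nM.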

Compound 3, half-maximal inhibitory concentration: 7 nM
Compound 3: middle estimate off by 1.7-fold (0.23 log units), on the high side; measured number inside the range.
By their numbers in this assay, from the lowest: compounds 1 and 2 (each within the scatter of the next); then compound 3.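

With hydrogen in place of methyl(phenylsulfonyl)amino, this assay shows a 3.5-fold higher number from compound 2 to compound 3 (0.54 log units; beyond the scatter), and with hydrogen in place of (dimethylcarbamoyl)amino it shows a 3.5-fold higher number from compound 1 to compound 3 (0.54 log units; beyond the scatter), so having a substituent on this saturated chain carbon does matter, which the exchange of one group for the other could not show. The loss is modest, since compound 3, with only a methyl left, still gives 7 nM, so most of the activity in this series does not rest on either group. Nothing at hand explains the difference.

From the compounds shown here alone, whether the gain needs a group as large as these remains open, and a simple amine or hydroxyl on the same carbon would bear on that. How a carboxylic acid there would compare with the two groups shown is also unknown.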